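Changing the aryl group on a shared core

A few compounds are considered here, and "the series" means these few. Any claim that something is new, unique, unknown or untested is made for them only; others in the source may bear on it.

In a functional assay on PC-3 cells (Homo sapiens) for cytotoxicity, read by sulforhodamine B assay, with a stated time of 48 h (a higher number here means a weaker inhibitor, a lower number a stronger inhibitor), compound 1 (`C[C@H]1CC[C@@H]2[C@@H](OC(=O)[C@]23CC(c2ccc(N(C)C)cc2)=NO3)[C@]2(C)C(=O)C=C[C@@]12O`) gives 6300 nM and compound 2 (`C[C@H]1CC[C@@H]2[C@@H](OC(=O)[C@]23CC(c2ccccc2Cl)=NO3)[C@]2(C)C(=O)C=C[C@@]12O`) gives 12000 nM. For the measured compounds named here, the only measured step, a 1.9-fold higher number from compound 1 to compound 2 (0.28 log units; within the scatter), stays within the scatter, so compound 2 cannot be told apart from compound 1 on these numbers. Compound 3 (`Cc1cccc(C2=NO[C@]3(C2)C(=O)O[C@@H]2[C@H]3CC[C@H](C)[C@]3(O)C=CC(=O)[C@@]23C)c1`) differs from compound 2 as follows: 3-methylphenyl in place of 2-chlorophenyl on a carbon with a double bond to nitrogen. This places 3-methylphenyl in place of 2-chlorophenyl on a carbon with a double bond to nitrogen. Going by the values given here, the one measured step bears on this change, since it replaced a group at that same carbon, and its size, a 1.9-fold higher number from compound 1 to compound 2 (0.28 log units; within the scatter), did not leave the scatter. No step beyond the scatter is therefore expected, and no direction can be called. The estimated change is a 1.3-fold lower number from compound 2 to compound 3 (0.12 log units; within the scatter). Compound 3 is expected at 9000 nM, with an estimated range of 4000 nM to 20000 nM.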

Compound 3, half-maximal inhibitory concentration: 66600 nM
The estimate for compound 3 lay 7.4-fold (0.87 log units) below the measured number, outside the stated range (above it).
By their numbers in this assay, from the lowest: compounds 1 and 2 (each within the scatter of the next); then compound 3.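

The group on the carbon with a double bond to nitrogen is not interchangeable in this assay: the first exchange there stayed within the scatter, but 3-methylphenyl gives a 5.6-fold higher number from compound 2 to compound 3 (0.74 log units; beyond the scatter) and an 11-fold higher number from compound 1 to compound 3 (1.02 log units; beyond the scatter). The position therefore responds to the choice of aryl group, even though 2-chlorophenyl and 3-methylphenyl have the same count of heavy atoms and each carries one six-membered aromatic ring of carbon only. Nothing at hand explains this difference.

The compounds shown leave open whether the higher number goes with the methyl group itself or with its place on the phenyl ring. Unsubstituted phenyl, 2-methylphenyl and 4-methylphenyl at the same carbon would separate those two readings.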